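The source may report more compounds than this note shows. Statements on the series, on what has been measured and on what is new or still open speak of the compounds shown alone.

Of the compounds shown here, three have been measured in a functional assay on HEK293 cells for agonist activity at Bile acid receptor (Homo sapiens); on this read-out higher numbers stand for larger maximal responses and lower numbers for smaller maximal responses. Compound 1 `CC(C)c1onc(-c2c(Cl)cccc2Cl)c1COc1ccc(NC(=O)c2ccc(C(=O)O)cc2)c(C(F)(F)F)n1` gives 21%, compound 2 `CC(C)c1onc(-c2c(Cl)cccc2Cl)c1COc1ccc(N(C)Cc2ccc(OCCO)cc2)c(C(F)(F)F)n1` gives 43%, and compound 3 `CC(Nc1ccc(C(=O)O)cc1)c1ccc(OCc2c(-c3c(Cl)cccc3Cl)noc2C2CC2)nc1C(F)(F)F` gives 59%. Compound 3 therefore reaches the largest maximal response of the three: its result lies beyond the scatter above compound 2 and further still above compound 1. Compound 4 `CC(Oc1ccc(C(=O)O)cc1)c1ccc(OCc2c(-c3c(Cl)cccc3Cl)noc2C2CC2)nc1C(F)(F)F` has not been measured. It differs from compound 3 in one place: 4-carboxyphenoxy in place of (4-carboxyphenyl)amino on a saturated chain carbon bound to an aromatic carbon and a saturated chain carbon The group that leaves carries two hydrogen-bond donors, the group that enters carries one. Within the data shown here, no measured pair shows this change, so nothing directly comparable exists. For compound 4 a moderate decrease in this assay is expected, a step of a number 14 percentage points lower from compound 3 to compound 4 (beyond the scatter). The estimated value for compound 4 is 45%, with a range from 20% to 75%.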

Compound 4, largest response reached (reported as efficacy), in percent of the reference or control that the assay uses: 70%
The estimate for compound 4 lay 25 percentage points below the measured number; the measured number falls inside the stated range.
By their numbers in this assay, from the lowest: compound 1; then compound 2; then compound 3; then compound 4.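

In this assay, putting 4-carboxyphenoxy in place of (4-carboxyphenyl)amino on this saturated chain carbon gives a number 11 percentage points higher from compound 3 to compound 4 (beyond the scatter) as a modest rise. For this pair, then, the amine hydrogen is not required for a large maximal response, and the linking nitrogen can give way to oxygen with a gain. No measurement here gives a reason for the rise. Still open, going by these compounds, is how a sulfur atom or a methylene group would compare with that oxygen. Also open, on these data alone, is what an ester in place of the carboxylic acid would do.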